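The source may report more compounds than this note shows. Statements on the series, on what has been measured and on what is new or still open speak of the compounds shown alone.

In an assay on isolated protein for binding affinity to Adrenergic receptor alpha-1 (Homo sapiens) (on this read-out higher numbers stand for weaker inhibition and lower numbers for stronger inhibition), compound 1, `COc1ccccc1N1CCN(CCn2c(=O)[nH]c3[nH]c(-c4ccccc4)cc3c2=O)CC1`, gives 1.99 nM. Compound 2, `O=c1[nH]c2[nH]c(-c3ccccc3)cc2c(=O)n1CCN1CCN(c2ccccc2Cl)CC1`, differs from compound 1 by chloro in place of methoxy on an aromatic carbon. Compound 2 gives 4.71 nM; that change made a 2.4-fold higher number from compound 1 to compound 2 (0.37 log units; beyond the scatter). Compound 3, `COc1ccc(-c2cc3c(=O)n(CCN4CCN(c5ccccc5OC)CC4)c(=O)[nH]c3[nH]2)cc1`, carries a different core, differing from compound 1 by methoxy in place of hydrogen on an aromatic carbon. Compound 3 gives 5.47 nM. Compound 4, `COc1ccccc1N1CCN(CCn2c(=O)[nH]c3[nH]c(-c4ccc(Cl)cc4)cc3c2=O)CC1`, has not been measured; it differs from compound 3 by chloro in place of methoxy on an aromatic carbon. This is the same kind of change as from compound 1 to compound 2, but not the same: there the place was ortho to a large group, here it is para to a large group. Because the earlier step was a 2.4-fold higher number from compound 1 to compound 2 (0.37 log units; beyond the scatter), compound 4 is expected to show a step of a 1.6-fold higher number from compound 3 to compound 4 (0.22 log units; within the scatter), with the position difference leaving it less certain. Compound 4 is estimated at 9 nM, between 3 nM and 27 nM.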

Compound 4, inhibition constant: 4.08 nM
For compound 4 the middle estimate is 2.2-fold (0.34 log units) above the measured one; the range from low to high includes it.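

In this assay, the swap of methoxy for chloro does not carry over as a fixed step from one core to the other: the same change on two cores in this assay, a 2.4-fold higher number (0.37 log units; beyond the scatter) from compound 1 to compound 2 and a 1.3-fold lower number (0.13 log units; within the scatter) from compound 3 to compound 4, 3.2-fold (0.50 log units) apart, beyond the scatter of two such steps. On the 4-methoxyphenyl group the swap gives a 1.3-fold lower number from compound 3 to compound 4 (0.13 log units; within the scatter), while chloro in place of hydrogen on the same ring gives a 2.1-fold higher number from compound 1 to compound 4 (0.31 log units; beyond the scatter). Among the compounds shown here, this rests on only two pairs with the swap at a different place in each, so it shows that the step cannot simply be transferred, but not why, nor whether core or place matters more.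

From the compounds shown here alone, it remains open how an amine or a carboxylic acid would behave in the place para to a large group. A third core could also show whether the swap gives yet another step.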